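A Fluorine Moved Around the Ring

The source may report more compounds than this note shows. Statements on the series, on what has been measured and on what is new or still open speak of the compounds shown alone.

Compound 1 `COc1cc2nc(/C=C/c3ccccc3)nc(N3CCC(CCNS(N)(=O)=O)CC3)c2cc1OC` is the weakest binder of the three compounds measured in an assay on cells for inhibition of Ectonucleotide pyrophosphatase/phosphodiesterase family member 1 (Homo sapiens), with a stated time of 60 min (on this read-out lower numbers stand for stronger inhibition and higher numbers for weaker inhibition), where compound 1 gives 1840 nM. Compound 2 `COc1cc2nc(/C=C/c3cccnc3)nc(N3CCC(CCNS(N)(=O)=O)CC3)c2cc1OC` gives 58 nM, and compound 3 `COc1cc2nc(/C=C/c3ccccc3F)nc(N3CCC(CCNS(N)(=O)=O)CC3)c2cc1OC` gives 211 nM. Compound 4 `COc1cc2nc(/C=C/c3ccc(F)cc3)nc(N3CCC(CCNS(N)(=O)=O)CC3)c2cc1OC` has not yet been measured; it differs from compound 1 by fluoro in place of hydrogen on an aromatic carbon. Within the data shown here, one measured step bears directly on this change: an 8.7-fold lower number from compound 1 to compound 3 (0.94 log units; beyond the scatter), which put the same fluoro onto a different aromatic carbon of the same ring. The larger step of a 32-fold lower number from compound 1 to compound 2 (1.50 log units; beyond the scatter) involves a different kind of change and only shows that this ring tolerates alteration. A modest step downward is therefore expected, a 3.7-fold lower number from compound 1 to compound 4 (0.57 log units; beyond the scatter). Compound 4 is thus estimated at 500 nM, with a range from 150 nM to 1800 nM.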

Compound 4, inhibition constant: 465 nM
Compound 4: middle estimate off by 1.1-fold (0.03 log units), on the high side; the range from low to high includes it.
By their numbers in this assay, from the lowest: compound 2; then compound 3; then compound 4; then compound 1.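

With fluoro para to a large group, the ring gives a 4.0-fold lower number from compound 1 to compound 4 (0.60 log units; beyond the scatter) and so the gain seen with compound 3 is not tied to one aromatic carbon. The choice of carbon still counts: moving from 2-fluorophenyl to 4-fluorophenyl gives a 2.2-fold higher number from compound 3 to compound 4 (0.34 log units; beyond the scatter) and the pyridin-3-yl group keeps its lead, with an 8.0-fold higher number from compound 2 to compound 4 (0.90 log units; beyond the scatter) on replacing it by 4-fluorophenyl. No measurement here explains these differences. On these data alone, whether chloro, methoxy or an amine on this same aromatic carbon would lower the number as fluoro does stays open.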